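Compound 4: Back to a Carbon Ring?

The source may hold more compounds than are shown below. What is called first, only, known or untested is meant among the compounds shown, and "the series" means these compounds.

Values in a functional assay on A2780 cells (Homo sapiens) for antiproliferative activity, read by MTT assay, with a stated time of 48 h (a lower number here means a stronger inhibitor, a higher number a weaker inhibitor), so far:
compound 1 `COc1ccc(-c2nc3cnccc3n2-c2cc(OC)c(OC)c(OC)c2)cc1O` gives > 20000 nM (a limit of the assay, not a number)
compound 2 `COc1ccc(-c2cc3c(cn2)[nH]c(=O)n3-c2cc(OC)c(OC)c(OC)c2)cc1O` gives 240 nM
compound 3 `COc1ccc(-c2cc3c(cn2)[nH]c(=O)n3-c2cc(OC)c(OC)c(OC)c2)cn1` gives 990 nM

Of the two true numbers, compound 3 at 990 nM holds the higher, making it the weaker inhibitor of that pair, and compound 2 is its nearest neighbour. Compound 4 `COc1ccc(-c2cc3c(cn2)[nH]c(=O)n3-c2cc(OC)c(OC)c(OC)c2)cc1C` differs from compound 3 in one place: 4-methoxy-3-methylphenyl in place of 6-methoxypyridin-3-yl on an aromatic carbon (the new group sits on an aromatic carbon of the core). Going by the values given here, its ring is of carbon only, like the one in compound 2, although a methyl group replaces the hydroxy of compound 2. Among the compounds with values here, one measured step bears on this, namely a 4.1-fold higher number from compound 2 to compound 3 (0.62 log units; beyond the scatter) and it ran from that carbon ring to 6-methoxypyridin-3-yl. Compound 4 partly reverses that swap, so a lower number is expected in this assay by a similar or slightly smaller amount. The expected change is a 2.5-fold lower number from compound 3 to compound 4 (0.39 log units; beyond the scatter) and it rests on that single step. Compound 4 is estimated at 400 nM with an expected range from 100 nM to 1600 nM in this measurement.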

Compound 4, half-maximal inhibitory concentration: 1530 nM
Estimate against measurement, compound 4: 3.8-fold (0.58 log units) below, and the stated range covers the measured number.
By their numbers in this assay, from the lowest: compound 2; then compounds 3 and 4 (each within the scatter of the next). At a limit, above all of these: compound 1.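

In this assay, a ring of carbon only does not by itself restore the activity of compound 2. Placing 4-methoxy-3-methylphenyl where 6-methoxypyridin-3-yl stood gives a 1.5-fold higher number from compound 3 to compound 4 (0.19 log units; within the scatter), so those two numbers cannot be told apart. Methyl in place of hydroxy on the otherwise identical ring gives a 6.4-fold higher number from compound 2 to compound 4 (0.80 log units; beyond the scatter), which ties the lower number of compound 2 to its hydroxy rather than to the carbon ring as such, at least among these compounds.

No measurement shown explains why this exchange matters. From the compounds shown here alone, whether an amino group or a fluorine atom in the place of that hydroxy would behave like the hydroxy or like the methyl remains open.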